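This account rests on a few compounds, and the source may have more. Where it says the series, first, only, none or still open, it means among the compounds named here.

Going by the values given here, the three compounds measured so far share one core, and compound 1 `Cc1cc(C)nc(SCc2cc(=O)c3cc(Cl)ccc3o2)n1` is the starting point. In a functional assay on MCF7 cells (Homo sapiens) for cytotoxicity, read by MTT assay, with a stated time of 72 h (a higher number here means a weaker inhibitor, a lower number a stronger inhibitor), compound 1 gives only a limit, > 25000 nM, and no number. Compound 3 `Cc1cc(O)cc2oc(=O)cc(CSc3nc4ccccc4[nH]3)c12` likewise gives only a limit in this assay, > 25000 nM. Compound 2 `Cc1nnc(SCc2coc3ccc(Cl)cc3c2=O)o1` gives a number in this assay, 5000 nM. Compound 1 therefore stands at the limit of > 25000 nM in this assay, at which 2 of the 3 values shown sit, and nothing finer than that is known about where it sits.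

Compound 4 `Cc1ccc2oc(CSc3nc(C)cc(C)n3)cc(=O)c2c1` differs from compound 1 by methyl in place of chloro on an aromatic carbon. Among the compounds with values here, no measured pair shows this exchange, so no step size for it has been observed. The change swaps one heavy atom for one heavy atom, and the starting value is a limit. For compound 4 the expected step is a number no higher from compound 1 to compound 4 (the limit leaves the size open), none beyond the usual scatter. Compound 4 is estimated at 25000 nM, within a range from 8000 nM to 80000 nM, and it is quite likely to come back as a limit again.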

Compound 4, half-maximal inhibitory concentration: > 25000 nM
Compound 4 ended at the assay's limit (the forecaster's own chance of this, stated with the estimate: 65%); the middle value lies on the limit itself.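

Compound 1 and compound 4 both end at a limit rather than a number, so no step can be read between them: the limit of > 25000 nM in this assay, at which 3 of the 4 values shown sit.

The compounds shown leave open whether methyl in place of chloro changes the result in this assay at all, and where either compound truly lies beyond that limit.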